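Anilinopiperazine succinimide series: second ring chloro step

A few compounds are considered here, and "the series" means these few. Any claim that something is new, unique, unknown or untested is made for them only; others in the source may bear on it.

Measured:
- compound 1, `CC1CC(=O)N(CC(=O)N2CCN(c3cccc(Cl)c3)CC2)C1=O`: 100 mg/kg
- compound 2, `CC1CC(=O)N(CC(=O)N2CCN(c3ccccc3)CC2)C1=O`: 300 mg/kg
- compound 3, `CCC1(C)CC(=O)N(CC(=O)N2CCN(c3ccc(Cl)cc3)CC2)C1=O`: 100 mg/kg

In a functional assay on the whole organism (strain CD1) with Mus musculus as the target, with a stated time of 0.5 h (a higher number here means that more compound is needed for the effect, a lower number that less compound is needed), compound 1 gives 100 mg/kg, and compound 3 gives 100 mg/kg, the two standing level at the digits shown and together the lowest numbers of the three; compound 2 gives 300 mg/kg, the highest. Among the compounds with values here, the one single-point step among them is a 3.0-fold higher number from compound 1 to compound 2 (0.48 log units; beyond the scatter), for hydrogen in place of chloro on an aromatic carbon, a modest step beyond the scatter.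

Compound 4, `CC1CC(=O)N(CC(=O)N2CCN(c3cccc(Cl)c3Cl)CC2)C1=O`, has not been measured. It differs from compound 1 by chloro in place of hydrogen on an aromatic carbon, the new group sitting on an aromatic carbon of a six-membered aromatic ring of carbon only, ortho to a chloro group. Within the data shown here, only the step from compound 1 to compound 2 bears on it, and only in the opposite direction: it shows that taking a chloro off this ring raises the number in this assay. Whether a second chloro lowers it further is not shown by any measured pair. The expectation is therefore a step of no change at the digits printed from compound 1 to compound 4 (within the scatter), at most within the scatter, with the estimate for compound 4 put at 100 mg/kg and a range from 30 mg/kg to 300 mg/kg.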

Compound 4, minimum effective dose: 100 mg/kg
The estimate for compound 4 equals the measured number at the digits printed; the measured number falls inside the stated range.
By their numbers in this assay, from the lowest: compounds 1, 3 and 4 (each within the scatter of the next); then compound 2.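

In this assay, within the data shown here, chloro in place of hydrogen on an aromatic carbon, ortho to a chloro group, gives no change at the digits printed from compound 1 to compound 4 (within the scatter), so going from 3-chlorophenyl to 2,3-dichlorophenyl adds nothing that can be read at this position, something the earlier compounds, with at most one chloro on this ring, could not show. The advantage over the unsubstituted ring survives the added chloro: 2,3-dichlorophenyl gives a 3.0-fold lower number from compound 2 to compound 4 (0.48 log units; beyond the scatter), a step of the same printed size as the reverse of the single-chloro change, a 3.0-fold higher number from compound 1 to compound 2 (0.48 log units; beyond the scatter), so within these three compounds the second chloro neither extends nor erodes that advantage. No measurement offered here accounts for this flat result at the new position.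

Open, going by these compounds, is whether a group other than chloro on this carbon, such as methoxy, methyl or trifluoromethyl, would shift the number, and whether a ring carrying the new chloro alone would match the 3-chlorophenyl compound. Among these compounds, also open is how 2,3-dichlorophenyl behaves alongside the ethyl and methyl groups of compound 3, since no single-place pair links compound 3 to the others.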